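The compounds below may be only part of what the source reports. "The series", "measured", "known", "first", "only" and "open" are said of these compounds alone.

In a functional assay on UACC-62 cells (Homo sapiens) for antiproliferative activity, read by sulforhodamine B assay, with a stated time of 48 h (a lower number here means a stronger inhibitor of growth, a higher number a weaker inhibitor of growth), compound 1 `Nc1nn(C(=O)Nc2ccc(Cc3ccccc3)cc2)c2ccccc12` gives only a limit of the assay, > 100000 nM. Compound 2 `Nc1nn(C(=O)Nc2ccc(Cc3ccccc3)cc2)c2ccc(Cl)cc12`, which carries chloro in place of hydrogen on an aromatic carbon, likewise gives only a limit, > 100000 nM. The step from compound 1 to compound 2 is therefore a step that the two limits leave unreadable from compound 1 to compound 2; both values sit at the limit of > 100000 nM in this assay, at which 2 of the 2 values shown sit, so compound 2 stands at that limit and nowhere more precisely. Compound 3 `Nc1ccc2c(c1)c(N)nn2C(=O)Nc1ccc(Cc2ccccc2)cc1` differs from compound 2 by amino in place of chloro on an aromatic carbon. For the measured compounds named here, the single measured step, from compound 1 to compound 2, is unreadable and concerns a different substituent, so no measured step bears on the present change with a readable size. The expected step from compound 2 to compound 3 is accordingly a number no higher from compound 2 to compound 3 (the limit leaves the size open), anchored only on the limit of compound 2. Compound 3 is therefore expected to give about 100000 nM, within a range of 30000 nM to 300000 nM, quite possibly again as a limit rather than a number.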

Compound 3, concentration for total growth inhibition: 12600 nM
Compound 3: middle estimate off by 7.9-fold (0.90 log units), on the high side, and the stated range ends above it.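

In this assay, this position on the shared core can shift the read-out once it carries amino: amino in place of chloro gives an at least 7.9-fold lower number from compound 2 to compound 3 (0.89 log units; beyond the scatter), and amino in place of hydrogen gives an at least 7.9-fold lower number from compound 1 to compound 3 (0.89 log units; beyond the scatter). For the compounds shown here, the earlier step, chloro in place of hydrogen, could not be read, so these are the first readable steps at this position. Both new steps start from a limit, so they set only a minimum size, and compound 3 alone of the three gives a number: the limit of > 100000 nM in this assay, at which 2 of the 3 values shown sit.

The compounds shown leave open whether the lower number is specific to amino or would also appear with a hydroxy, methylamino or acetamido group at this position. As far as these compounds go, how far the true values of compound 1 and compound 2 lie from compound 3 also stays open.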